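The compounds below may be only part of what the source reports. "The series", "measured", "known", "first", "only" and "open" are said of these compounds alone.

Compound 3 `CCOC(=O)COc1ccc2c(=O)cc(-c3cc(C(C)(C)C)c(O)c(C(C)(C)C)c3)oc2c1` stands level with compound 1 `CC(C)(C)c1cc(-c2cc(=O)c3ccc(OCCO)cc3o2)cc(C(C)(C)C)c1O` and compound 2 `CC(C)(C)c1cc(-c2cc(=O)c3ccc(OCc4ccc5ccccc5n4)cc3o2)cc(C(C)(C)C)c1O`: in a functional assay for inhibition (a lower number here means a stronger inhibitor, a higher number a weaker inhibitor), compound 1 gives 3000 nM, compound 2 gives 3000 nM, and compound 3 gives 3000 nM. The steps of no change at the digits printed from compound 1 to compound 2 (within the scatter), no change at the digits printed from compound 1 to compound 3 (within the scatter) and no change at the digits printed from compound 2 to compound 3 (within the scatter) all fall within the scatter, although each swaps a sizeable group on the saturated chain carbon bound to an oxygen on the aromatic ring. Compound 4 `COc1ccc2c(=O)cc(-c3cc(C(C)(C)C)c(O)c(C(C)(C)C)c3)oc2c1` differs from compound 3 by hydrogen in place of ethoxycarbonyl on a saturated chain carbon bound to an oxygen on an aromatic ring. The three measured steps at this carbon bear directly on it; none moved the read-out, so no step beyond the scatter is expected in either direction, and the step of no change at the digits printed from compound 3 to compound 4 (within the scatter) is estimated as flat. Compound 4 is therefore expected to give 3000 nM, within 1500 nM to 6000 nM.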

Compound 4, half-maximal inhibitory concentration: 1000 nM
Estimate against measurement, compound 4: 3.0-fold (0.48 log units) above; measured number below the stated range.
By their numbers in this assay, from the lowest: compound 4; then compounds 1, 2 and 3 (each within the scatter of the next).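

In this assay this saturated chain carbon now shows a step beyond the scatter: hydrogen in place of ethoxycarbonyl (a 3.0-fold lower number from compound 3 to compound 4 (0.48 log units; beyond the scatter)), of quinolin-2-yl (a 3.0-fold lower number from compound 2 to compound 4 (0.48 log units; beyond the scatter)) and of hydroxymethyl (a 3.0-fold lower number from compound 1 to compound 4 (0.48 log units; beyond the scatter)). The three larger groups read level with one another, so only the bare methoxy separates from them, and the step does not depend on which of the three groups leaves. No accompanying measurement bears on the reason for this step. On these data alone, whether a methyl or a carboxylic acid on this carbon reads with compound 4 or with compounds 1, 2 and 3 remains open.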